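Bromo on the Fused Ring: One Step, Two Cores

A few compounds are considered here, and "the series" means these few. Any claim that something is new, unique, unknown or untested is made for them only; others in the source may bear on it.

Measured compounds in a functional assay on cells (Cancer cell lines, Homo sapiens) for cytotoxicity, read by sulforhodamine B assay, with a stated time of 48 h; on this read-out lower numbers stand for stronger inhibition of growth and higher numbers for weaker inhibition of growth:
compound 1, `COc1ccc(C2=NN(C3=NC(=O)/C(=C4\C(=O)Nc5ccccc54)S3)C(c3ccc(Cl)cc3)C2)cc1`, gives 77500 nM
compound 2, `COc1ccc(C2=NN(C3=NC(=O)/C(=C4\C(=O)Nc5ccc(Br)cc54)S3)C(c3ccc(Cl)cc3)C2)cc1`, gives 120 nM
compound 3, `CN(C)c1ccc(C2CC(c3ccccc3)=NN2C2=NC(=O)/C(=C3\C(=O)Nc4ccccc43)S2)cc1`, gives 1110 nM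

Within the first core, the change bromo in place of hydrogen on an aromatic carbon produced a 650-fold lower number from compound 1 to compound 2 (2.81 log units; beyond the scatter). The difference between the core of compound 1 and the core of compound 3 is not broken down here; compound 3 sits between the two measured values of the first core in this assay.

Compound 4, `CN(C)c1ccc(C2CC(c3ccccc3)=NN2C2=NC(=O)/C(=C3\C(=O)Nc4ccc(Br)cc43)S2)cc1`, carries the same change relative to compound 3: bromo in place of hydrogen on an aromatic carbon, at the same place as in the first pair. Within the data shown here, compound 4 is expected to give 8 nM in this assay, a step of a 140-fold lower number from compound 3 to compound 4 (2.14 log units; beyond the scatter), because the only precedent is a 650-fold lower number from compound 1 to compound 2 (2.81 log units; beyond the scatter); as it rests on one pair, the expected step is set somewhat smaller, within 1 nM to 80 nM.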

Compound 4, concentration for 50% growth inhibition: 210 nM
For compound 4 the middle estimate is 26-fold (1.42 log units) below the measured one; the whole stated range lies below it.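

In this assay, bromo in place of hydrogen on an aromatic carbon again lowers the number, a 5.3-fold lower number from compound 3 to compound 4 (0.72 log units; beyond the scatter), so the direction of the step carries over to the second core. Among these compounds, the size of the step does not carry over, and the two steps differ: the same change on two cores in this assay, a 650-fold lower number (2.81 log units; beyond the scatter) from compound 1 to compound 2 and a 5.3-fold lower number (0.72 log units; beyond the scatter) from compound 3 to compound 4, 120-fold (2.09 log units) apart, beyond the scatter of two such steps With only two pairs, the notes show that the size of this step varies with the core, but not which of the differences between the two cores sets it.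

Still open, on these data alone, is whether chloro, fluoro or nitrile at the same place gives a step like either bromo step. Also open, as far as these compounds go, is how the step behaves on further cores.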